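Swapping a Chlorophenyl Ether for a Methoxyphenyl Ether

A few compounds are considered here, and "the series" means these few. Any claim that something is new, unique, unknown or untested is made for them only; others in the source may bear on it.

Within the data shown here, compound 2 `O=C(O)C[C@@H]1CCCN1c1ccc(Oc2cccc(Cl)c2)cc1` is one of two compounds measured in a functional assay on cells for agonist activity at Free fatty acid receptor 1 (Mus musculus), read by FLIPR and calcium flux, with a stated time of 100 s; on this read-out higher numbers stand for an effect only at larger amounts of compound and lower numbers for an effect already at smaller amounts. In this assay compound 2 reaches only the limit > 16000 nM, so no number is known for it. Its closest measured relative, compound 1 `Cc1ccccc1COc1ccc(N2CCC[C@H]2CC(=O)O)cc1`, gives 3400 nM in this assay. Among the measured compounds shown here, the one measured step, an at least 4.7-fold higher number from compound 1 to compound 2 (0.67 log units; beyond the scatter), is the only direct evidence, and it rests on (the limit of > 16000 nM in this assay, at which 1 of the 2 values shown sits). Compound 3 `COc1ccc(Oc2ccc(N3CCC[C@H]3CC(=O)O)cc2)cc1` differs from compound 2 by 4-methoxyphenyl in place of 3-chlorophenyl on an oxygen on an aromatic ring. For the measured compounds named here, no measured step covers this exact exchange; the step from compound 1 to compound 2 shows only that the chlorophenyl ether is weak. With nothing to suggest a return toward compound 1, compound 3 is expected to stay at a similar weak level, a step estimated as an at least 1.0-fold lower number from compound 2 to compound 3 (0.02 log units; that floor lies within the scatter). The estimate for compound 3 is therefore 15000 nM, ranging from 4000 nM to 50000 nM, with a real chance that only a limit is reported again.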

Compound 3, half-maximal effective concentration: > 33000 nM
Compound 3: no number, only a limit; the forecaster's own chance of this, stated with the estimate: 55%; middle value at least 2.2-fold (0.34 log units) from the limit.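

In this assay compound 3 gives only a limit, > 33000 nM, not a number. Putting 4-methoxyphenyl in place of 2-methylbenzyl on this oxygen gives an at least 9.7-fold higher number from compound 1 to compound 3 (0.98 log units; beyond the scatter), so a second phenyl group carried directly on the oxygen, with a different substituent, also falls well short of compound 1. The step between compound 2 and compound 3 cannot be read, as both values are limits, so nothing can be said about how 4-methoxyphenyl and 3-chlorophenyl rank against each other.

Compound 1 differs from both of these compounds in its benzyl carbon and in its ring substituent, and the compounds shown do not tell these two features apart. A plain benzyl group or a 4-methoxybenzyl group on this oxygen would bear directly on that open question.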